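The source may report more compounds than this note shows. Statements on the series, on what has been measured and on what is new or still open speak of the compounds shown alone.

Compound 1 `O=C1/C(=C/c2ccncc2)CN(S(=O)(=O)c2ccc([N+](=O)[O-])cc2)C/C1=C\c1ccccc1F`: 11300 nM
Compound 2 `O=C1/C(=C/c2ccncc2)CN(S(=O)(=O)c2ccccc2)C/C1=C\c1ccccc1C(F)(F)F`: 7020 nM

In a functional assay on HepG2 cells (Homo sapiens) for cytotoxicity, read by MTT assay, with a stated time of 24 h (on this read-out higher numbers stand for weaker inhibition and lower numbers for stronger inhibition), compound 2 lies within the usual scatter of compound 1, so neither number stands apart. Compound 3 `O=C1/C(=C/c2ccncc2)CN(S(=O)(=O)c2ccc([N+](=O)[O-])cc2)C/C1=C\c1ccccc1C(F)(F)F` differs from compound 2 by one change nitro in place of hydrogen on an aromatic carbon that puts nitro in place of hydrogen on an aromatic carbon, turning phenyl to 4-nitrophenyl. Within the data shown here, no measured pair shows this change alone. Compound 1 also carries 4-nitrophenyl and gives 11300 nM in this test, close to compound 2 at 7020 nM on the same scale. No shift beyond the scatter is therefore expected in this assay and the expected 1.1-fold higher number from compound 2 to compound 3 (0.06 log units; within the scatter) is small. Compound 3 is estimated at 8000 nM with a range of 3500 nM to 18000 nM expected.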

Compound 3, half-maximal inhibitory concentration: 13400 nM
Compound 3: middle estimate off by 1.7-fold (0.22 log units), on the low side, within the range that was stated.
By their numbers in this assay, from the lowest: compounds 2, 1 and 3 (each within the scatter of the next).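

Turning phenyl to 4-nitrophenyl gives a 1.9-fold higher number from compound 2 to compound 3 (0.28 log units; within the scatter) in this assay and so provides the first direct reading of this change, which does not separate the two compounds. Trifluoromethyl in place of fluoro on an aromatic carbon gives a 1.2-fold higher number from compound 1 to compound 3 (0.07 log units; within the scatter) and likewise does not separate its pair. Nothing available explains why these numbers sit so close together. As far as these compounds go, whether an amine or a carboxylic acid in place of nitro at this position would move the number beyond the scatter remains open. So does whether nitro would behave the same way with other groups elsewhere on the shared core.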